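Swapping an amide for a sulfonamide on a stable series

This account rests on a few compounds, and the source may have more. Where it says the series, first, only, none or still open, it means among the compounds named here.

Measured compounds:
compound 1, `COc1ccc(-c2scc3c(N4CC[C@@H](NC(C)=O)C4)nc(C)nc23)cc1OC`, > 95%
compound 2, `CC(=O)N[C@@H]1CCN(c2cc(C)nn3c(-c4cccs4)c(C)nc23)C1`, > 95%
compound 3, `CCCCCC(=O)N[C@@H]1CCN(c2cc(C)nn3c(-c4ccc(OC)c(OC)c4)c(C)nc23)C1`, > 95%

In an ADME assay on microsomes from liver (Mus musculus) for metabolic stability, read by LC-MS, with NADPH named in the record, with a stated time of 60 min, tested at 1 uM, in the absence of a further agent (a lower number here means that less of the compound is left, a higher number that more of the compound is left), compound 1 gives > 95%, which is a limit of the assay rather than a number. Compound 2 likewise gives > 95%, again a limit. Compound 3 stands at > 95%, also a limit, so no numerical position for compound 3 can be read off. All three measured compounds share this position, as the limit of > 95% in this assay, at which 3 of the 3 values shown sit, records.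

Compound 4, `COc1ccc(-c2c(C)nc3c(N4CC[C@@H](NS(=O)(=O)c5ccc(C#N)cc5)C4)cc(C)nn23)cc1OC`, has not yet been measured. It differs from compound 3 by (4-cyanophenyl)sulfonyl in place of pentylcarbonyl on an amine nitrogen. Among the measured compounds shown here, since no step between measured compounds is available, the direction can only be guessed from compound 3 sitting at > 95%. Compound 4 is expected to remain at or near this limit, with a step from compound 3 of about a number at least 5 percentage points lower from compound 3 to compound 4 (that floor lies within the scatter), which is not expected to exceed the scatter. The estimate for compound 4 is 90%, with a range from 70% to 99%.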

Compound 4, percent of the compound remaining: > 95%
Compound 4: no number, only a limit; the forecaster's own chance of this, stated with the estimate: 55%; at least 5 percentage points between middle value and limit.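

No step can be read from compound 3 to compound 4, because both values are the same limit of the assay: the limit of > 95% in this assay, at which 4 of the 4 values shown sit.

The compounds shown leave open whether (4-cyanophenyl)sulfonyl in place of pentylcarbonyl changes the percent of the compound remaining in this assay at all.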